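The source may hold more compounds than are shown below. What is called first, only, known or untested is meant among the compounds shown, and "the series" means these compounds.

Three compounds have been measured in an assay on Cortex for displacement of a labelled ligand from Voltage-dependent L-type calcium channel subunit alpha-1D (Rattus norvegicus); on this read-out lower numbers stand for stronger inhibition and higher numbers for weaker inhibition:

Compound 1 `COC(=O)C1=C(C)N=C(C)/C(=C(/O)OC)C1c1cccc(OCc2nonc2C)c1` gives 720 nM.
Compound 2 `COC(=O)C1=C(C)N=C(C)/C(=C(/O)OC)C1c1ccccc1OCc1nonc1C` gives 59 nM.
Compound 3 `COC(=O)C1=C(C)N=C(C)/C(=C(/O)OC)C1c1ccccc1OCc1nonc1C(N)=O` gives 880 nM.

Compound 3 stands at the weak end of these three numbers; compound 1 lies close by, within the scatter, while compound 2 is well separated, since going a 15-fold higher number from compound 2 to compound 3 (1.17 log units; beyond the scatter). Among the compounds with values here, that single step, carbamoyl in place of methyl on the aromatic carbon, is the only measured step that bears on what follows.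

Compound 4 `COC(=O)C1=C(C)N=C(C)/C(=C(/O)OC)C1c1ccccc1OCc1no[n+]([O-])c1C#N` is not yet measured. It differs from compound 3 in one place: a group of 8 heavy atoms (3 carbon, 3 nitrogen, 2 oxygen; one five-membered aromatic ring with 3 hetero atoms) in place of a group of 8 heavy atoms (3 carbon, 3 nitrogen, 2 oxygen; one five-membered aromatic ring with 3 hetero atoms), on a saturated chain carbon bound to an oxygen on an aromatic ring. The carbamoyl, with its hydrogen-bond donor, leaves, and a nitrile on an oxadiazole bearing an oxide enters. Within the data shown here, the carbamoyl accompanied the large rise from compound 2 to compound 3, so its removal points toward a lower number, but the oxide has no precedent among the measured compounds, which leaves the size uncertain. The estimate for compound 4 is therefore a moderate step downward, a 2.5-fold lower number from compound 3 to compound 4 (0.40 log units; beyond the scatter), giving an expected 350 nM, within a range from 90 nM to 1400 nM.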

Compound 4, half-maximal inhibitory concentration: 27 nM
Estimate against measurement, compound 4: 13-fold (1.11 log units) above; measured number outside the range, below it.
By their numbers in this assay, from the lowest: compound 4; then compound 2; then compounds 1 and 3 (each within the scatter of the next).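

In this assay, the group on the saturated chain carbon bound to an oxygen on an aromatic ring can change the number sharply even when its size stays the same: two groups with the same count of heavy atoms give a 33-fold lower number from compound 3 to compound 4 (1.51 log units; beyond the scatter). Size alone therefore does not decide the outcome at this position. Within the data shown here, a group larger than the one in compound 2 also need not cost anything here, since the change gives a 2.2-fold lower number from compound 2 to compound 4 (0.34 log units; beyond the scatter), whereas the earlier carbamoyl change raised the number.

The nitrile and the oxide arrive together, so these compounds cannot show which of them matters, or how an ethyl group or a carboxylic acid in the nitrile's place would read. No available evidence explains the size of these steps.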